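Aryl exchange on the carbon double-bonded to nitrogen

The source may hold more compounds than are shown below. What is called first, only, known or untested is meant among the compounds shown, and "the series" means these compounds.

Compound 3 `CO/N=C(\CCN1CCN(c2ccccn2)CC1)c1ccccc1C` gives 11.4 nM in an assay on HEK293 cells for displacement of a labelled ligand from D(4) dopamine receptor (Homo sapiens) (on this read-out lower numbers stand for stronger inhibition and higher numbers for weaker inhibition), the lowest of the three numbers in hand. Compound 1 `O/N=C(\CCN1CCN(c2ccccn2)CC1)c1ccccc1` gives 25.4 nM in this assay, a higher number that lies beyond the scatter, and compound 2 `CCO/N=C(\CCN1CCN(c2nccs2)CC1)c1ccccc1` gives 168 nM in this assay, the highest of the three and far beyond the scatter from compound 3. Compounds 1 and 3 differ in more than one place, so their gap cannot be tied to a single change.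

Compound 4 `CO/N=C(\CCN1CCN(c2ccccn2)CC1)c1ccc(Cl)cc1` has not been measured in this assay. It differs from compound 3 in one place: 4-chlorophenyl in place of 2-methylphenyl on a carbon with a double bond to nitrogen. Among the measured compounds shown here, no measured pair shows this change on its own, so the size of the step rests on judgement only. The expectation is a modest rise in the number, at or just beyond the scatter, which is the step of a 1.9-fold higher number from compound 3 to compound 4 (0.29 log units; within the scatter) that the estimate implies. Compound 4 is accordingly expected to give about 22 nM in this assay, with a plausible range from 7 nM to 70 nM.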

Compound 4, inhibition constant: 38.2 nM
The estimate for compound 4 lay 1.7-fold (0.24 log units) below the measured number, within the range that was stated.
By their numbers in this assay, from the lowest: compound 3; then compounds 1 and 4 (each within the scatter of the next); then compound 2.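

Among the compounds shown here, the first step that changes one place alone falls on this carbon: 4-chlorophenyl in place of 2-methylphenyl gives a 3.4-fold higher number from compound 3 to compound 4 (0.53 log units; beyond the scatter) in this assay, so the number at this position depends on which aryl group is carried. The two groups match in heavy-atom count, ring type, hydrogen-bond donors and acceptors, and net charge, so none of these counts separates them. Nothing measured here bears on why the number rises.

Going by these compounds, this step exchanges both the substituent, methyl for chlorine, and its ring position, so the share of each remains open; 2-chlorophenyl and 4-methylphenyl on the core of compound 3 would separate the two. Unsubstituted phenyl on that same core would show whether the 2-methyl or the 4-chloro group moves the number from that baseline.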